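Swapping an aryl ketone for a propyl ketone

The source may report more compounds than this note shows. Statements on the series, on what has been measured and on what is new or still open speak of the compounds shown alone.

Three ketones built on one shared core have been tested in an ADME assay on L929 cells (Mus musculus) for cytotoxicity, read by resazurin assay, with a stated time of 72 h; a lower number here means a stronger inhibitor, a higher number a weaker inhibitor. Compound 1, `O=C(c1ccn(-c2ccc3c(c2)B(O)OC3)c1)c1ccccc1Cl`, reaches only the assay limit: in this assay compound 1 gives > 10 ug/mL, which is a limit and not a number. Compound 2, `COc1ccccc1C(=O)c1ccn(-c2ccc3c(c2)B(O)OC3)c1`, carries methoxy in place of chloro; in this assay compound 2 gives > 10 ug/mL, again a limit. Compound 3, `NCc1ccc(C(=O)c2ccn(-c3ccc4c(c3)B(O)OC4)c2)cc1`, gives > 10 ug/mL in this assay, once more a limit rather than a measured value. Because all three sit at the limit of > 10 ug/mL in this assay, at which 3 of the 3 values shown sit, the steps a step that the two limits leave unreadable from compound 1 to compound 2, a step that the two limits leave unreadable from compound 1 to compound 3 and a step that the two limits leave unreadable from compound 2 to compound 3 cannot be sized, and compound 3 cannot be told apart from compounds 1 and 2 on these numbers. Compound 4, `CCCC(=O)c1ccn(-c2ccc3c(c2)B(O)OC3)c1`, differs from compound 3 by propyl in place of 4-(aminomethyl)phenyl on a carbonyl carbon. Among the measured compounds shown here, none of the measured steps can guide this change, since each is unreadable. The expected step in this assay is a step that the limit leaves unreadable from compound 3 to compound 4, that is, nothing beyond the scatter. Compound 4 is therefore estimated at 15 ug/mL, with a range from 5 ug/mL to 50 ug/mL.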

Compound 4, half-maximal inhibitory concentration: > 10 ug/mL
Compound 4 ended at the assay's limit; the forecaster's own chance of this, stated with the estimate: 80%; the middle value does not contradict the limit.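

The steps linking compound 4 to compound 1, compound 2 and compound 3 cannot be read in this assay, because all four compounds stop at one limit rather than a number: the limit of > 10 ug/mL in this assay, at which 4 of the 4 values shown sit.

The compounds shown leave open what concentration of any of them would actually reach the half-maximal effect on these cells.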